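Bromo for carboxy on the pyridyl ring of the oxadiazole ketones

This account rests on a few compounds, and the source may have more. Where it says the series, first, only, none or still open, it means among the compounds named here.

Working notes on a small set of ketones. Compound 1 `Cn1nc(-c2ccccn2)nc1C(=O)CCCCCCc1ccccc1` gives 30000 nM in an assay for inhibition of Fatty-acid amide hydrolase 1 (Rattus norvegicus); on this read-out higher numbers stand for weaker inhibition and lower numbers for stronger inhibition; compound 2 `O=C(CCc1ccc(-c2ccccc2)cc1)c1nnc(-c2ccccn2)o1` gives 0.3 nM; compound 3 `O=C(O)c1cccc(-c2nnc(C(=O)CCc3ccc(-c4ccccc4)cc3)o2)n1` gives 48 nM. Compound 3 thus stands second highest of the three numbers, nearest to compound 2 and far from compound 1. Among the compounds with values here, the one step that bears on the next change is a 160-fold higher number from compound 2 to compound 3 (2.20 log units; beyond the scatter). Compound 4 `O=C(CCc1ccc(-c2ccccc2)cc1)c1nnc(-c2cccc(Br)n2)o1` differs from compound 3 by bromo in place of carboxy on an aromatic carbon. As compound 2, without donor or acceptor at that carbon, gives 0.3 nM, a step back down is expected, though not necessarily the whole way: the estimate for compound 4 is 3 nM (range 0.5 nM to 20 nM), i.e. an expected 16-fold lower number from compound 3 to compound 4 (1.20 log units; beyond the scatter).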

Compound 4, inhibition constant: 3.6 nM
The estimate for compound 4 lay 1.2-fold (0.08 log units) below the measured number; the range from low to high includes it.
By their numbers in this assay, from the lowest: compound 2; then compound 4; then compound 3; then compound 1.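

Bromo in place of carboxy gives a 13-fold lower number from compound 3 to compound 4 (1.12 log units; beyond the scatter) in this assay, so a substituent at this carbon need not cost as much as carboxy does. Bromo, with no hydrogen-bond donor or acceptor, still leaves a 12-fold higher number from compound 2 to compound 4 (1.08 log units; beyond the scatter) as the step from hydrogen, so a cost remains at this position without either feature. No supporting measurement bears on either step. The compounds shown leave open how a methyl group, an amine or a methyl ester at this carbon would compare, and whether these steps hold with a different chain on the ketone.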